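Swapping One Dimethylpyridinyl Group for Another

A few compounds are considered here, and "the series" means these few. Any claim that something is new, unique, unknown or untested is made for them only; others in the source may bear on it.

Of the compounds shown here, two with a shared core have been tested so far in an in vitro ADME assay on microsomes from liver (Canis lupus familiaris) for metabolic stability; a higher number here means faster removal of the compound, a lower number slower removal. Compound 1 (`CC[C@H](C)[C@@H]1C(=O)N[C@H](C2Cc3ccccc3C2)C(=O)N1[C@@H](C(=O)N1CCOCC1)c1cnc(C)cc1C`) gives 4 mL.min-1.g-1 there, while compound 2 (`CC[C@H](C)[C@@H]1C(=O)N[C@H](C2Cc3ccccc3C2)C(=O)N1[C@@H](C(=O)N(C)C)c1ccc(C)nc1C`) gives 1 mL.min-1.g-1 there, the lower number of the two and apart from compound 1 by more than the usual scatter. Compound 3 (`CC[C@H](C)[C@@H]1C(=O)N[C@H](C2Cc3ccccc3C2)C(=O)N1[C@@H](C(=O)N(C)C)c1cnc(C)cc1C`) differs from compound 2 in one place (4,6-dimethylpyridin-3-yl in place of 2,6-dimethylpyridin-3-yl on a saturated chain carbon bound to an amide-type nitrogen in a ring and a carbonyl carbon), on a saturated chain carbon bound to an amide-type nitrogen in a ring and a carbonyl carbon. Going by the values given here, no measured pair shows this swap alone. The expectation leans on compound 1, which carries the entering 4,6-dimethylpyridin-3-yl group and gives 4 mL.min-1.g-1 in this assay although it also differs from compound 3 elsewhere. The expected move is a 2.0-fold higher number from compound 2 to compound 3 (0.30 log units; within the scatter) toward faster removal, about as large as the usual scatter. The estimated value for compound 3 is 2 mL.min-1.g-1 with an expected range from 1 mL.min-1.g-1 to 5 mL.min-1.g-1 in this test.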

Compound 3, intrinsic clearance in microsomes: 1 mL.min-1.g-1
Beside the measured number, compound 3's estimate is 2.0-fold (0.30 log units) above it; the measured number falls inside the stated range.
By their numbers in this assay, from the lowest: compounds 2 and 3 (each within the scatter of the next); then compound 1.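

In this assay, exchanging 2,6-dimethylpyridin-3-yl for 4,6-dimethylpyridin-3-yl on the saturated chain carbon gives no change at the digits printed from compound 2 to compound 3 (within the scatter) and so shows that this rearrangement of the two methyl groups leaves the reading within the scatter. With 4,6-dimethylpyridin-3-yl held fixed, dimethylamino in place of morpholin-4-yl on the carbonyl carbon gives a 4.0-fold lower number from compound 1 to compound 3 (0.60 log units; beyond the scatter) and so provides the only step beyond the scatter among these compounds. Nothing at hand explains either result.

On these data alone, only two dimethylpyridinyl arrangements appear on the chain carbon, so the outcome with a plain phenyl ring or an unsubstituted pyridine there remains open. Also open, as far as these compounds go, are whether the morpholin-4-yl step carries over with 2,6-dimethylpyridin-3-yl in place and how a piperidine or pyrrolidine amide would read.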